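Swapping the Acidic Group at the Far Ring

The source may report more compounds than this note shows. Statements on the series, on what has been measured and on what is new or still open speak of the compounds shown alone.

Three compounds share one core and differ only in the group carried on the far aromatic ring. Compound 1 `CCCCc1nc(Cl)c(COC)n1Cc1ccc(-c2ccccc2-c2nn[nH]n2)cc1` gives 6 in a physicochemical assay (Rattus norvegicus). Compound 2 `CCCCc1nc(Cl)c(COC)n1Cc1ccc(-c2ccccc2NS(=O)(=O)C(F)(F)F)cc1` gives 4.5, and the change a number 1.50 log units lower from compound 1 to compound 2 (beyond the scatter) shows how strongly this single group sets the read-out. Compound 3 `CCCCc1nc(Cl)c(CO)n1Cc1ccc(-c2ccccc2NC(=O)C(F)(F)F)cc1` stands highest of the three, giving 9.5, which lies well above both companions.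

Compound 4 `CCCCc1nc(Cl)c(CO)n1Cc1ccc(-c2ccccc2C(=O)NOC)cc1` is the next member. It differs from compound 3 in one place: methoxycarbamoyl in place of ((trifluoromethyl)carbonyl)amino on an aromatic carbon. Among the measured compounds shown here, no measured pair covers this particular exchange; the step from compound 1 to compound 2 concerns other groups and only tells that such exchanges can move this assay by a large amount. Given the value of compound 3 at 9.5, a methoxycarbamoyl group is expected to give up its proton somewhat less readily, so a modest upward step is estimated, a number 1.00 log units higher from compound 3 to compound 4 (beyond the scatter). Compound 4 is therefore expected to show 10.5, within a range from 9.5 to 11.5.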

Compound 4, acid dissociation constant: 10.9
Compound 4: the middle estimate sits 0.40 log units below what was measured, within the range that was stated.
By their numbers in this assay, from the lowest: compound 2; then compound 1; then compound 3; then compound 4.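

Placing methoxycarbamoyl in this position gives a number 1.40 log units higher from compound 3 to compound 4 (beyond the scatter) in this assay, so a change here can move the number upward by a large amount, whereas the earlier step, a number 1.50 log units lower from compound 1 to compound 2 (beyond the scatter), moved it downward. The groups that leave and enter each count one hydrogen-bond donor and no net charge, so matching on those two counts does not guarantee a similar number in this pair. Nothing given here accounts for the size of this step.

The compounds shown leave open how a carboxylic acid would read in this same position on the shared core. They also leave open whether methoxycarbamoyl would give a similar number on the core of compound 1, which carries a methoxymethyl group where compound 4 does not.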